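Methylamino for ethylsulfanyl on the shared core

This account rests on a few compounds, and the source may have more. Where it says the series, first, only, none or still open, it means among the compounds named here.

Of the compounds shown here, three with the shared core have been tested in an in vitro functional assay on 1321-N1 cells for agonist activity at P2Y purinoceptor 6 (Homo sapiens), read by scintillation proximity assay and inositol phosphate accumulation; a higher number here means that more compound is needed for the effect, a lower number that less compound is needed. Compound 1 `Nc1nc(=O)ccn1[C@@H]1O[C@H](COP(=O)(O)OP(=O)(O)O)[C@@H](O)[C@H]1O` gives only a limit, >= 100000 nM. Compound 2 `O=c1[nH]c(=S)ccn1[C@@H]1O[C@H](COP(=O)(O)O)[C@@H](O)[C@H]1O` likewise gives only a limit, > 100000 nM. Compound 3 `CCSc1nc(=O)ccn1[C@@H]1O[C@H](COP(=O)(O)O)[C@@H](O)[C@H]1O` also gives only a limit, > 100000 nM. Compound 3 thus stands where two of the three values sit, at the limit of > 100000 nM in this assay, at which 2 of the 3 values shown sit, while the remaining value sits at the limit of >= 100000 nM in this assay, at which 1 of the 3 values shown sits; no number separates any of these compounds in this assay.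

Compound 4 `CNc1nc(=O)ccn1[C@@H]1O[C@H](COP(=O)(O)O)[C@@H](O)[C@H]1O` is not yet measured. It differs from compound 3 by methylamino in place of ethylsulfanyl on an aromatic carbon. Going by the values given here, no measured pair shows a comparable step, so the size of the step in this assay is open, and the expected direction can rest only on the fact that compound 3 reaches the limit itself. Compound 4 is therefore expected to stay near that limit, with an estimated step that the limit leaves unreadable from compound 3 to compound 4, and its value is estimated at 150000 nM, within 20000 nM to 1000000 nM.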

Compound 4, half-maximal effective concentration: > 100000 nM
Compound 4: a limit, no number; the forecaster's own chance of this, stated with the estimate: 80%; the middle value is on the limit's open side.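

Compound 3 and compound 4 each give only a limit in this assay, so no step between them can be read: the limit of > 100000 nM in this assay, at which 3 of the 4 values shown sit.

The compounds shown leave open how methylamino and ethylsulfanyl compare on this aromatic carbon, and which change to the shared core, if any, would give a number in this assay.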